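Aryl amide variation on a shared quinazoline thioacetamide core

This account rests on a few compounds, and the source may have more. Where it says the series, first, only, none or still open, it means among the compounds named here.

Measured compounds:
compound 1, `O=C(CSc1nc(Nc2ccccc2)c2ccccc2n1)Nc1cccc(Cl)c1` — in a functional assay on MGC-803 cells (Homo sapiens) for inhibition, read by MTT assay, with a stated time of 72 h (on this read-out higher numbers stand for weaker inhibition and lower numbers for stronger inhibition), compound 1 gives 14300 nM
compound 2, `C=CC(=O)Nc1cccc(NC(=O)CSc2nc(Nc3ccccc3)c3ccccc3n2)c1` — in this assay compound 2 gives 7310 nM
compound 3, `O=C(CSc1nc(Nc2ccccc2)c2ccccc2n1)Nc1ccc([N+](=O)[O-])cc1` — in this assay compound 3 gives only a limit, > 50000 nM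

Compound 1 holds the highest of the two plain numbers; the nearest, compound 2, lies within the scatter, a 2.0-fold lower number from compound 1 to compound 2 (0.29 log units; within the scatter). Compound 3 sits at the assay limit (the limit of > 50000 nM in this assay, at which 1 of the 3 values shown sits), so its steps from compound 1 and compound 2 are read as lower bounds, an at least 3.4-fold higher number from compound 1 to compound 3 (0.54 log units; beyond the scatter) and an at least 6.8-fold higher number from compound 2 to compound 3 (0.83 log units; beyond the scatter).

The next compound is compound 4, `O=C(CSc1nc(Nc2ccccc2)c2ccccc2n1)Nc1ccc(Cl)c(Cl)c1`. It differs from compound 1 by chloro in place of hydrogen on an aromatic carbon. Among the measured compounds shown here, no measured step adds a chloro to the aryl amide; the closest comparisons are the swap of the whole aryl group in an at least 3.4-fold higher number from compound 1 to compound 3 (0.54 log units; beyond the scatter), which weakened inhibition, and the replacement of chloro in a 2.0-fold lower number from compound 1 to compound 2 (0.29 log units; within the scatter), which stayed within the scatter. Neither speaks directly for a second chloro, so a step in this assay of no more than the scatter is expected in either direction, a 1.2-fold lower number from compound 1 to compound 4 (0.08 log units; within the scatter). Compound 4 is accordingly estimated at 12000 nM, with a range from 5000 nM to 35000 nM.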

Compound 4, half-maximal inhibitory concentration: 37900 nM
Compound 4: the middle estimate sits 3.2-fold (0.50 log units) below what was measured; the measured number lies above the stated range.
By their numbers in this assay, from the lowest: compounds 2 and 1 (each within the scatter of the next); then compound 4. At a limit, above all of these: compound 3.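

Adding chloro to the aromatic carbon ortho to a chloro group and para to a large group, which turns 3-chlorophenyl into 3,4-dichlorophenyl, gives a modest step in this assay, a weakening of inhibition beyond the scatter: a 2.7-fold higher number from compound 1 to compound 4 (0.42 log units; beyond the scatter). Set against the 3-((vinylcarbonyl)amino)phenyl amide, the same dichloro ring also lies on the weaker side by a modest step, a 5.2-fold higher number from compound 2 to compound 4 (0.71 log units; beyond the scatter), so among the compounds shown, the two with a group para to the large group, compound 3 and compound 4, both give weaker inhibition than compound 1 and compound 2, with none going against this. Compound 3 gives only a limit: the limit of > 50000 nM in this assay, at which 1 of the 4 values shown sits. The step from that limit is known only as a floor, which lies within the scatter and sets no order: an at least 1.3-fold lower number from compound 3 to compound 4 (0.12 log units; that floor lies within the scatter).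

As far as these compounds go, it remains open whether the loss belongs to chloro itself or to any group at this place, which a fluoro, a methoxy or an amine there would help to separate. From the compounds shown here alone, it is equally open how a 4-chlorophenyl amide without the 3-chloro would compare with compound 4.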